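Trading the Distal Phenyl for a Single Fluorine

The source may report more compounds than this note shows. Statements on the series, on what has been measured and on what is new or still open speak of the compounds shown alone.

Three amides built on one shared core have been tested in a functional assay on CHO cells for inhibition of transient receptor potential cation channel subfamily V member 1 (Homo sapiens); a higher number here means a weaker inhibitor, a lower number a stronger inhibitor. Compound 1 `Cc1ccc(/C=C/C(=O)Nc2ccc3c(c2)OCCO3)cc1` carries a methyl on an aromatic carbon, and in this assay compound 1 gives 1100 nM. Compound 2 `CCCCc1ccc(/C=C/C(=O)Nc2ccc3c(c2)OCCO3)cc1` lengthens that substituent, and compound 2 gives 2700 nM. Compound 3 `O=C(/C=C/c1ccc(-c2ccccc2)cc1)Nc1ccc2c(c1)OCCO2` places a phenyl on the same aromatic carbon; for compound 3 this assay returned only a limit, > 4000 nM, so its standing is known only as a floor (the limit of > 4000 nM in this assay, at which 1 of the 3 values shown sits). Lengthening methyl to butyl gave a 2.5-fold higher number from compound 1 to compound 2 (0.39 log units; beyond the scatter); replacing methyl with phenyl gave an at least 3.6-fold higher number from compound 1 to compound 3 (0.56 log units; beyond the scatter); replacing butyl with phenyl gave an at least 1.4-fold higher number from compound 2 to compound 3 (0.17 log units; that floor lies within the scatter).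

Compound 4 `O=C(/C=C/c1ccc(F)cc1)Nc1ccc2c(c1)OCCO2` moves the other way: fluoro in place of phenyl on an aromatic carbon. The two steps toward phenyl both weakened inhibition, so removing it should recover potency. The expectation rests chiefly on compound 1, whose small methyl goes with 1100 nM. Compound 4 is therefore expected near 1500 nM, within 500 nM to 5000 nM, an estimated step of an at least 2.6-fold lower number from compound 3 to compound 4 (0.42 log units; beyond the scatter).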

Compound 4, half-maximal inhibitory concentration: > 4000 nM
Compound 4 gave a limit, no number; the forecaster's own chance of this, stated with the estimate: 15%; middle value at least 2.6-fold (0.42 log units) away from the limit.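

Replacing phenyl with fluoro did not bring back a measured number: in this assay compound 4 also returns only a limit, > 4000 nM, and the step from compound 3 cannot be read, as both values are limits of the same kind: the limit of > 4000 nM in this assay, at which 2 of the 4 values shown sit.

What is new is that a single fluorine on this aromatic carbon is not enough to keep inhibition within the readable range, since fluoro in place of methyl gave an at least 3.6-fold higher number from compound 1 to compound 4 (0.56 log units; beyond the scatter). Against butyl, fluoro gave an at least 1.4-fold higher number from compound 2 to compound 4 (0.17 log units; that floor lies within the scatter), so this comparison fixes no order between those two compounds.

Going by these compounds, how far compound 3 and compound 4 actually lie beyond the limit remains open. So does whether chloro, methoxy or ethyl on this carbon would match the methyl of compound 1.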